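The source may report more compounds than this note shows. Statements on the series, on what has been measured and on what is new or still open speak of the compounds shown alone.

Measured so far:
Compound 1 `CC#CC(CC(=O)O)c1ccc(OCc2ccc3nc(-c4ccc(CC)cc4)cn3c2)cc1`: 496 nM
Compound 2 `CC#CC(CC(=O)O)c1ccc(OCc2ccc3nc(-c4ccc(F)cc4)cn3c2)cc1`: 623 nM

Both compounds were tested in an assay on isolated protein for agonist activity at Free fatty acid receptor 1 (Homo sapiens); on this read-out higher numbers stand for an effect only at larger amounts of compound and lower numbers for an effect already at smaller amounts. Going by the values given here, compound 2 sits within the usual scatter of compound 1, so the two numbers cannot be told apart; the only measured step, exchanging ethyl for fluoro on the same aromatic carbon, gave a 1.3-fold higher number from compound 1 to compound 2 (0.10 log units; within the scatter). Compound 3 `CC#CC(CC(=O)O)c1ccc(OCc2ccc3nc(-c4ccccc4F)cn3c2)cc1` has not yet been measured. It differs from compound 2 by 2-fluorophenyl in place of 4-fluorophenyl on an aromatic carbon. Among the compounds with values here, no measured step shifts the fluorine to another carbon of that ring, so nothing bears directly on this change, and the one step that exists was itself too small to read. The expected step for compound 3 is therefore a 1.1-fold higher number from compound 2 to compound 3 (0.05 log units; within the scatter), within the scatter. Compound 3 is expected to give 700 nM in this assay, with a range from 300 nM to 1600 nM.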

Compound 3, half-maximal effective concentration: 583 nM
Beside the measured number, compound 3's estimate is 1.2-fold (0.08 log units) above it, within the range that was stated.
By their numbers in this assay, from the lowest: compounds 1, 3 and 2 (each within the scatter of the next).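

In this assay, moving the fluorine around the ring gives a 1.1-fold lower number from compound 2 to compound 3 (0.03 log units; within the scatter) and so no readable change: 2-fluorophenyl and 4-fluorophenyl on this aromatic carbon cannot be told apart. Exchanging 4-ethylphenyl for 2-fluorophenyl gives a 1.2-fold higher number from compound 1 to compound 3 (0.07 log units; within the scatter) and is equally unreadable, so all three compounds now sit within the scatter of one another, whichever of these groups the ring carries and wherever the fluorine stands among the two placements shown. No measurement is available that could explain this flat result.

Still open, going by these compounds, is whether a group of a different kind on that phenyl ring, such as an amine or a carboxylic acid, would move the number beyond the scatter. The same question stands for a longer chain in place of the ethyl group of compound 1.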